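Shifting the methoxy group from compound 2 to compound 4

The source may report more compounds than this note shows. Statements on the series, on what has been measured and on what is new or still open speak of the compounds shown alone.

Compound 1 `CC1(C)CCCC2=CC=C(C=O)CC[C@]21C` gives 191000 nM
Compound 2 `C=C1CCC[C@]2(C)CCC(c3cn(-c4ccc(OC)cc4)nn3)=CC[C@@]12C` gives 58900 nM
Compound 3 `C=C1CCC[C@]2(C)CCC(c3cn(CC(=O)Nc4ccc(C)cc4)nn3)=CC[C@@]12C` gives 254000 nM

These three compounds were tested in a functional assay on DU-145 cells (Homo sapiens) for cytotoxicity, read by MTT assay, with a stated time of 48 h (on this read-out lower numbers stand for stronger inhibition and higher numbers for weaker inhibition), and compound 2 has the lowest number of the set. Its gaps to compound 1 and to compound 3 both lie beyond the scatter, which makes it the most potent of the three, although all three values are high.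

Compound 4 (`C=C1CCC[C@]2(C)CCC(c3cn(-c4cccc(OC)c4)nn3)=CC[C@@]12C`) has not yet been measured. It holds the same atoms as compound 2, joined differently, with 3-methoxyphenyl in place of 4-methoxyphenyl on an aromatic nitrogen. Among the measured compounds shown here, no two measured compounds differ in one place only, so the data give no direct guide to this change. The expectation therefore starts from compound 2 at 58900 nM and assumes that a change this small will not shift the result much. For the measured compounds named here, compound 2 is also the lowest of only three numbers, so any drift is expected toward weaker inhibition. The estimate means an expected step of a 1.2-fold higher number from compound 2 to compound 4 (0.07 log units; within the scatter) with nothing beyond the scatter. In this assay the estimated value of compound 4 is 70000 nM (expected range 30000 nM to 160000 nM).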

Compound 4, half-maximal inhibitory concentration: 38900 nM
Compound 4: middle estimate off by 1.8-fold (0.26 log units), on the high side, within the range that was stated.
By their numbers in this assay, from the lowest: compounds 4 and 2 (each within the scatter of the next); then compounds 1 and 3 (each within the scatter of the next).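

Among the compounds shown here, compounds 2 and 4 form the first pair in this set that differs in one place only, so they give the first direct reading of the aryl group on the aromatic nitrogen of the five-membered ring. In this assay, 3-methoxyphenyl in place of 4-methoxyphenyl gives a 1.5-fold lower number from compound 2 to compound 4 (0.18 log units; within the scatter), so the two placements of the methoxy group cannot be told apart, and this change leaves the read-out where it was within normal repeat variation. For the compounds shown here, nothing available accounts for the two placements reading alike, and the pair shows only that this particular swap makes no clear difference.

On these data alone, it remains open whether the methoxy group contributes at all, and whether a plain phenyl on that nitrogen, or an amine or a carboxylic acid in place of the methoxy group on the ring, would read differently from compound 2. As far as these compounds go, it is also open whether any group at this nitrogen, such as a longer chain ending in a morpholine, could move the number beyond the scatter while the shared core stays unchanged.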